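Pyrrole for thiophene on the Z-configured core

This account rests on a few compounds, and the source may have more. Where it says the series, first, only, none or still open, it means among the compounds named here.

Three compounds share a core carrying a bromoacrylamide. Compound 1 `C=C(Br)C(=O)Nc1ccc2c(c1)/C(=C/c1cccs1)C(=O)N2` gives 230 nM in a functional assay on HL-60 cells (Homo sapiens) for antiproliferative activity, read by MTT assay, with a stated time of 72 h (on this read-out higher numbers stand for weaker inhibition and lower numbers for stronger inhibition), the second highest of the three numbers. Its nearest neighbour is compound 3 `C=C(Br)C(=O)Nc1ccc2c(c1)CC(=O)N2`, which lacks the thienyl group altogether and gives 350 nM in this assay, within the scatter of compound 1. Within the data shown here, compound 2 `C=C(Br)C(=O)Nc1ccc2c(c1)/C(=C\c1cccs1)C(=O)N2` gives 15 nM in this assay, and the step of a 15-fold lower number from compound 1 to compound 2 (1.19 log units; beyond the scatter) is the only measured step among the three; it rests on the fact that compounds 1 and 2 differ only in the configuration as drawn and says nothing about swapping one heteroaryl ring for another.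

Compound 4 `C=C(Br)C(=O)Nc1ccc2c(c1)/C(=C/c1ccc[nH]1)C(=O)N2` keeps the configuration of compound 1 and changes only the pendant ring: 1H-pyrrol-2-yl in place of thiophen-2-yl on a double-bonded chain carbon bound to a double-bonded ring carbon. Among the measured compounds shown here, no measured step speaks to this exchange, and the values of compound 1 and compound 3 show that the thienyl group in this geometry adds little. Compound 4 is therefore expected to sit close to compound 1, with a step of a 1.1-fold higher number from compound 1 to compound 4 (0.04 log units; within the scatter) that is not expected to pass beyond the scatter. The estimate for compound 4 is 250 nM, within a range from 80 nM to 800 nM.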

Compound 4, half-maximal inhibitory concentration: 140 nM
For compound 4 the middle estimate is 1.8-fold (0.25 log units) above the measured one, within the range that was stated.
By their numbers in this assay, from the lowest: compound 2; then compounds 4, 1 and 3 (each within the scatter of the next, the first and the last beyond it).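

In this assay, 1H-pyrrol-2-yl in place of thiophen-2-yl on a double-bonded chain carbon bound to a double-bonded ring carbon gives a 1.6-fold lower number from compound 1 to compound 4 (0.22 log units; within the scatter) and so stays within the scatter. Among these compounds, the earlier compounds spoke only to the configuration of the double bond and to the presence of the thienyl group, whereas this pair is the first reading of the identity of the ring itself: in this configuration, a ring with nitrogen and a hydrogen-bond donor reads the same as a ring with sulfur and a hydrogen-bond acceptor. Nothing at hand bears on why the exchange leaves the number within the scatter.

As far as these compounds go, whether the pyrrole ring in the configuration of compound 2, which gives 15 nM with thiophen-2-yl, would match that compound remains open. From the compounds shown here alone, how a furan-2-yl or phenyl ring, or a pyrrole with a methyl group on its nitrogen, would read at this place also remains open.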